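A few compounds are considered here, and "the series" means these few. Any claim that something is new, unique, unknown or untested is made for them only; others in the source may bear on it.

Measured so far in this series:

compound 1 `ClCc1ccc(Cn2cnc3c(Cl)ncnc32)cc1`: 57500 nM
compound 2 `ClCc1cccc(Cn2cnc3ncnc(Cl)c32)c1`: 6600 nM
compound 3 `ClCc1ccc(Cn2cnc3c(Cl)nc(Cl)nc32)cc1`: 52500 nM

All three numbers come from a functional assay on A498 cells (Homo sapiens) for cytotoxicity, read by sulforhodamine B assay, with a stated time of 48 h; a higher number here means that more compound is tolerated, a lower number that less compound is tolerated. Compound 1 and compound 2 contain the same atoms joined differently; the difference between the two cores is not broken down here. In this assay compound 2 gives the lowest number of the three, and its gaps to compound 3 and to compound 1 both lie beyond the scatter.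

Compound 3 differs from compound 1 by a single change, (chloro in place of hydrogen on an aromatic carbon). That change produced a 1.1-fold lower number from compound 1 to compound 3 (0.04 log units; within the scatter).

Compound 4 `ClCc1cccc(Cn2cnc3nc(Cl)nc(Cl)c32)c1` has not yet been measured in this assay. It stands to compound 2 as compound 3 stands to compound 1: the change is the same, (chloro in place of hydrogen on an aromatic carbon), at the same place on the core.

For the measured compounds named here, the expectation for compound 4 rests on the one measured instance of this change. Because a 1.1-fold lower number from compound 1 to compound 3 (0.04 log units; within the scatter) lies within the scatter, compound 4 is expected to stay close to compound 2. The step is expected to be a 1.0-fold lower number from compound 2 to compound 4 (0.02 log units; within the scatter). Compound 4 is estimated at 6300 nM, with a range from 2500 nM to 16000 nM.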

Compound 4, concentration lethal to 50% of the cells: 5370 nM
Estimate against measurement, compound 4: 1.2-fold (0.07 log units) above, and the stated range covers the measured number.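

In this assay the new step is a 1.2-fold lower number from compound 2 to compound 4 (0.09 log units; within the scatter), so chloro in place of hydrogen on an aromatic carbon, between two ring nitrogen atoms, makes no readable difference on this core. Carried from one core to the other, the change behaves alike, and the two steps cannot be told apart: the same change on two cores in this assay, a 1.1-fold lower number (0.04 log units; within the scatter) from compound 1 to compound 3 and a 1.2-fold lower number (0.09 log units; within the scatter) from compound 2 to compound 4, 1.1-fold (0.05 log units) apart, within the scatter of two such steps. For the compounds shown here, this shows that the change was neutral within the scatter on two cores, but it rests on only two pairs in one cell assay and does not show that the change would stay neutral on any further core or in any other read-out.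

The compounds shown leave open whether a group other than chloro at this place, such as an amine, a methoxy group or a longer chain, would move the number beyond the scatter. They also leave open whether a step of any size at this place would carry from one core to the other, since neither step here departs from the scatter.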